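Cyclobutyl in Place of Isopropyl on the Sulfonamide Nitrogen

This account rests on a few compounds, and the source may have more. Where it says the series, first, only, none or still open, it means among the compounds named here.

Compound 3 `CC(C)NS(=O)(=O)c1ccc(S(=O)(=O)N2CCC[C@@H](C(=O)N3CCN(c4nc(C(C)C)no4)CC3)C2)cc1` carries an isopropylsulfamoyl group on an aromatic carbon, and in a functional assay on MIA PaCa-2 cells (Homo sapiens) for inhibition, read by MTT assay, with a stated time of 3 days (a lower number here means a stronger inhibitor, a higher number a weaker inhibitor), compound 3 gives 200 nM. Among the three compounds measured it stands second highest. Compound 1 `CC(C)c1noc(N2CCN(C(=O)[C@@H]3CCCN(S(=O)(=O)c4ccc(S(=O)(=O)NC5CC5)cc4)C3)CC2)n1` gives 300 nM in this assay, and compound 2 `CCN(CC)C(=O)c1ccc(S(=O)(=O)N2CCC[C@@H](C(=O)N3CCN(c4nc(C(C)C)no4)CC3)C2)cc1` gives 70 nM. The step of a 2.9-fold higher number from compound 2 to compound 3 (0.46 log units; beyond the scatter) lies beyond the scatter, whereas the step of a 1.5-fold lower number from compound 1 to compound 3 (0.18 log units; within the scatter) lies within it.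

Compound 4 `CC(C)c1noc(N2CCN(C(=O)[C@@H]3CCCN(S(=O)(=O)c4ccc(S(=O)(=O)NC5CCC5)cc4)C3)CC2)n1` differs from compound 3 only on the sulfonamide nitrogen: cyclobutyl in place of isopropyl on a sulfonamide nitrogen. Among the compounds with values here, the single measured step at that same position, a 1.5-fold lower number from compound 1 to compound 3 (0.18 log units; within the scatter), changed nothing beyond the scatter. The larger steps of a 4.3-fold lower number from compound 1 to compound 2 (0.63 log units; beyond the scatter) and a 2.9-fold higher number from compound 2 to compound 3 (0.46 log units; beyond the scatter) concern a different group on the aromatic carbon, so they do not bear on this exchange. Within the data shown here, only one comparison at the sulfonamide nitrogen exists, so the expectation rests on a single pair. On that basis compound 4 is expected to remain close to compound 3 in this assay, with a step of no change at the digits printed from compound 3 to compound 4 (within the scatter) that is not expected to exceed the scatter. The estimate for compound 4 is 200 nM, with a range from 90 nM to 450 nM.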

Compound 4, half-maximal inhibitory concentration: 200 nM
Estimate against measurement, compound 4: no gap at the digits printed; the measured number falls inside the stated range.
By their numbers in this assay, from the lowest: compound 2; then compounds 3, 4 and 1 (each within the scatter of the next).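

In this assay, within the data shown here, the cyclobutyl group, with its four-membered non-aromatic ring of carbon only, gives no change at the digits printed from compound 3 to compound 4 (within the scatter) against isopropyl and a 1.5-fold lower number from compound 1 to compound 4 (0.18 log units; within the scatter) against cyclopropyl on the sulfonamide nitrogen, so three different groups at this position now stay within the scatter of one another, where the earlier compounds offered only a single pair. The separation from the diethylcarbamoyl group also holds for this new sulfamoyl group, with a 2.9-fold higher number from compound 2 to compound 4 (0.46 log units; beyond the scatter) and so a step beyond the scatter, of the same modest size as the one seen for isopropyl. No measurement shown here offers a reason for either result.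

The compounds shown leave open whether a sulfonamide nitrogen carrying a larger ring such as cyclohexyl, an aromatic ring such as phenyl, or a chain ending in a hydroxyl or an amine would stay as close to these three. They also leave open whether a cyclic amide such as a pyrrolidine carbonyl on the aromatic carbon would match the diethylcarbamoyl group in this assay.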